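Adding Two Methoxy Groups to a Side-Chain Phenyl

This account rests on a few compounds, and the source may have more. Where it says the series, first, only, none or still open, it means among the compounds named here.

Compound 1 `COc1ccc(/C=C/C[C@H]2C[C@@H]([C@@H](O)c3ccc(OC)c(OC)c3)CO[C@@H]2c2ccc(OC)c(OC)c2)cc1` gives 12200 nM in a functional assay on HeLa cells (Homo sapiens) for cytotoxicity, read by WST assay, with a stated time of 48 h (on this read-out higher numbers stand for weaker inhibition and lower numbers for stronger inhibition), compound 2 `COc1cccc([C@H](O)[C@H]2CO[C@H](c3ccc(OC)c(OC)c3)[C@@H](C/C=C/c3ccc(OC)c(OC)c3)C2)c1` gives 21200 nM, and compound 3 `COc1ccc([C@H]2OC[C@H]([C@@H](O)c3ccc(OC)c(OC)c3)C[C@@H]2C/C=C/c2ccccc2)cc1OC` gives 14800 nM. Compound 3 stands second highest of the three numbers, within the scatter of both compound 1 and compound 2. Compound 4 `COc1ccc(/C=C/C[C@H]2C[C@@H]([C@@H](O)c3ccc(OC)c(OC)c3)CO[C@@H]2c2ccc(OC)c(OC)c2)cc1OC` differs from compound 3 in one place: 3,4-dimethoxyphenyl in place of phenyl on a double-bonded chain carbon bound to a double-bonded chain carbon. For the measured compounds named here, the only measured step that touches this region is a 1.2-fold higher number from compound 1 to compound 3 (0.08 log units; within the scatter), a change that stayed within the scatter. On that basis no step beyond the scatter is expected in this assay for compound 4, and the expected step is a 1.1-fold lower number from compound 3 to compound 4 (0.06 log units; within the scatter). Compound 4 is therefore estimated at 13000 nM, with a range from 6500 nM to 26000 nM.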

Compound 4, half-maximal inhibitory concentration: 23800 nM
Compound 4: the middle estimate sits 1.8-fold (0.26 log units) below what was measured, within the range that was stated.
By their numbers in this assay, from the lowest: compounds 1, 3, 2 and 4 (each within the scatter of the next).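

In this assay 3,4-dimethoxyphenyl in place of phenyl on the side chain stays within the scatter (a 1.6-fold higher number from compound 3 to compound 4 (0.21 log units; within the scatter)), so this position accepts both methoxy groups together without a readable shift. The single methoxy additions stay within it too (a 1.1-fold higher number from compound 2 to compound 4 (0.05 log units; within the scatter); a 2.0-fold higher number from compound 1 to compound 4 (0.29 log units; within the scatter)). The same methoxy removal reads alike on two cores: the same change on two cores in this assay, a 1.2-fold higher number (0.08 log units; within the scatter) from compound 1 to compound 3 and a 1.1-fold lower number (0.05 log units; within the scatter) from compound 4 to compound 2, 1.4-fold (0.13 log units) apart, within the scatter of two such steps. Still open, going by these compounds, is whether an amine or a carboxylic acid on this phenyl, or a longer chain carrying it, would move the number beyond the scatter.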